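Series notes: ethyl for tert-butyl on the aryl sulfide

This account rests on a few compounds, and the source may have more. Where it says the series, first, only, none or still open, it means among the compounds named here.

Compound 3 `CC(C)(C)c1ccc(SCc2ccc(C(=O)Nc3ccccc3N)cc2)cc1` stands lowest of the three compounds measured in a functional assay on A-375 cells (Homo sapiens) for inhibition, read by CCK-8 assay, with a stated time of 72 h, tested at 8 uM; a lower number here means less inhibition of growth, a higher number more inhibition of growth at the concentration tested: compound 3 gives 33.1%. The nearest compound is compound 2 `Nc1ccccc1NC(=O)c1ccc(CSc2cccc(F)c2)cc1`, which gives 76.3%, and the furthest is compound 1 `COc1ccc(SCc2ccc(C(=O)Nc3ccccc3N)cc2)cc1`, which gives 81.8%; both gaps lie beyond the scatter. Among the measured compounds shown here, the one step that leads into compound 3, a number 48.7 percentage points lower from compound 1 to compound 3 (beyond the scatter), is the large step of the set, whereas a number 5.5 percentage points lower from compound 1 to compound 2 (within the scatter) changes little.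

Compound 4 `CCc1ccc(SCc2ccc(C(=O)Nc3ccccc3N)cc2)cc1` differs from compound 3 by ethyl in place of tert-butyl on an aromatic carbon. The change sits on the same aromatic carbon that a number 48.7 percentage points lower from compound 1 to compound 3 (beyond the scatter) concerned, where tert-butyl came in for methoxy and the number fell by a large margin. Ethyl carries fewer heavy atoms than tert-butyl, though it is not methoxy, so a partial return toward the number of compound 1 is expected in this assay rather than no change. The step of a number 21.9 percentage points higher from compound 3 to compound 4 (beyond the scatter) is therefore expected to run upward and beyond the scatter. For the measured compounds named here, no measured step in the set involves an ethyl, so the size of the return is uncertain and the range is set wide. Compound 4 is estimated at 55%, within 30% to 80%.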

Compound 4, percent growth inhibition at one concentration: 71.1%
Compound 4: middle estimate off by 16.1 percentage points, on the low side; low and high end bracket the measured number.
By their numbers in this assay, from the lowest: compound 3; then compounds 4, 2 and 1 (each within the scatter of the next, the first and the last beyond it).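

Within this assay, the aromatic carbon para to a large group accepts a carbon-only substituent, since a number 38 percentage points higher from compound 3 to compound 4 (beyond the scatter) shows that the low number of compound 3 does not extend to ethyl; among the compounds shown, the large loss belongs to tert-butyl alone. Ethyl does not fully match methoxy, as a number 10.7 percentage points lower from compound 1 to compound 4 (beyond the scatter) leaves a modest gap, whereas a number 5.2 percentage points lower from compound 2 to compound 4 (within the scatter) shows that the 4-ethylphenyl and 3-fluorophenyl groups on the sulfur cannot be told apart in this read-out. Nothing available on these compounds accounts for the contrast between ethyl and tert-butyl at this carbon.

The compounds shown leave open where the number begins to fall as the alkyl group grows, which an isopropyl group or a longer chain such as butyl at the same carbon would help to place. Also open, as far as these compounds go, is how a strongly different group there, such as an amine or a carboxylic acid, would read, and whether the order seen at this single concentration holds across a full concentration range.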